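A few compounds are considered here, and "the series" means these few. Any claim that something is new, unique, unknown or untested is made for them only; others in the source may bear on it.

Working notes on the series. For the measured compounds named here, compound 2 `COc1cc2cc(Oc3ccc(NC(=O)Nc4ccc(Cl)c(C(F)(F)F)c4)cc3)c(C)nc2cc1OC` gives in a functional assay on HCT-116 cells (Homo sapiens) for inhibition, read by sulforhodamine B assay, with a stated time of 48 h (a lower number here means a stronger inhibitor of growth, a higher number a weaker inhibitor of growth), 3840 nM, the lowest of the two numbers measured so far; compound 1 `COc1cc2cc(Oc3ccc(NC(=O)Nc4cccc(C(F)(F)F)c4)cc3)c(C)nc2cc1OC` gives 5840 nM in this assay, and the step of a 1.5-fold lower number from compound 1 to compound 2 (0.18 log units; within the scatter) stays within the scatter. Compound 3 `COc1cc2cc(Oc3ccc(NC(=O)Nc4ccc(Cl)c(Cl)c4)cc3)c(C)nc2cc1OC` differs from compound 2 by chloro in place of trifluoromethyl on an aromatic carbon. Going by the values given here, only one measured step bears on this change at all, a 1.5-fold lower number from compound 1 to compound 2 (0.18 log units; within the scatter), and it concerns a chloro entering at a different place, not a chloro replacing a trifluoromethyl; no measured step covers the change itself. Among the compounds with values here, since the one step is within the scatter, the expected step is a 1.0-fold lower number from compound 2 to compound 3 (0.00 log units; within the scatter), that is, nothing beyond the scatter, in either direction. Compound 3 is accordingly estimated at 3800 nM in this assay, with a range from 1500 nM to 9500 nM.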

Compound 3, concentration for total growth inhibition: 10500 nM
Beside the measured number, compound 3's estimate is 2.8-fold (0.44 log units) below it; the measured number lies above the stated range.
By their numbers in this assay, from the lowest: compounds 2, 1 and 3 (each within the scatter of the next, the first and the last beyond it).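

In this assay, for the compounds shown here, this place on the aromatic ring gives the first step beyond the scatter: with the neighbouring chloro kept, chloro in place of trifluoromethyl gives a 2.7-fold higher number from compound 2 to compound 3 (0.44 log units; beyond the scatter), so the group held here does register, though only modestly. The earlier pair, which differed by a chloro entering elsewhere, showed nothing of this. Set against the 3-(trifluoromethyl)phenyl group, the 3,4-dichlorophenyl group gives a 1.8-fold higher number from compound 1 to compound 3 (0.25 log units; within the scatter), so these two are not separated, and no measurement on hand accounts for either step.

Open, on these data alone, is how a fluoro, a nitrile or an amine would stand in this place relative to trifluoromethyl and chloro. Also open, as far as these compounds go, is whether the step from trifluoromethyl to chloro holds on a ring without the other chloro.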